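The compounds below may be only part of what the source reports. "The series", "measured", "known", "first", "only" and "open" are said of these compounds alone.

Compound 1 `O=C1c2ccccc2C(=O)N1c1nc(-c2ccc(F)cc2)cs1` gives 37200 nM in a functional assay on PC-3 cells (Homo sapiens) for antiproliferative activity, read by MTT assay, with a stated time of 48 h; a lower number here means a stronger inhibitor, a higher number a weaker inhibitor.
Compound 2 `O=C1c2ccccc2C(=O)N1c1nc(-c2ccc(Cl)cc2)cs1` gives 44900 nM in this assay.
Compound 3 `O=C1c2ccccc2C(=O)N1c1nc(-c2ccc([N+](=O)[O-])cc2)cs1` gives 41800 nM in this assay.

Compound 1 has the lowest of these three numbers, yet it is not set apart: the steps of a 1.2-fold higher number from compound 1 to compound 2 (0.08 log units; within the scatter) and a 1.1-fold higher number from compound 1 to compound 3 (0.05 log units; within the scatter) both stay within the scatter, so the three compounds cannot be told apart in this assay. Compound 4 `O=C1c2ccc(F)cc2C(=O)N1c1nc(-c2ccc(F)cc2)cs1` differs from compound 1 by fluoro in place of hydrogen on an aromatic carbon. Among the measured compounds shown here, the measured steps each swap a group on an aromatic carbon at a different place, so none bears directly on this change; they show only that such single swaps have not moved the number. A step beyond the scatter is therefore not expected, and compound 4 is estimated to give 37000 nM, between 15000 nM and 90000 nM, a step of a 1.0-fold lower number from compound 1 to compound 4 (0.00 log units; within the scatter).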

Compound 4, half-maximal inhibitory concentration: 39500 nM
Compound 4: middle estimate off by 1.1-fold (0.03 log units), on the low side; the measured number falls inside the stated range.
By their numbers in this assay, from the lowest: compounds 1, 4, 3 and 2 (each within the scatter of the next).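

Among the compounds shown here, the earlier swaps all sat at a different place, so this is the first look at the six-membered aromatic ring of the fused system. Adding fluoro in place of hydrogen there leaves the number in this assay within the scatter (a 1.1-fold higher number from compound 1 to compound 4 (0.03 log units; within the scatter)), so this place, like the earlier one, has not moved the number with a single swap. Nothing available here accounts for this result. As far as these compounds go, whether an amine, a carboxylic acid or a longer chain at this place would move the number stays open. So does the effect of fluoro on the other carbons of this ring.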